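The compounds below may be only part of what the source reports. "The series", "measured", "known", "first", "only" and "open" are said of these compounds alone.

Measured in a functional assay on HeLa cells (Homo sapiens) for inhibition, read by CCK-8 assay, with a stated time of 48 h; a lower number here means a stronger inhibitor, a higher number a weaker inhibitor:
compound 1 `COc1cc(-c2ccnc3cc(-c4ccc(N(C)C)cc4)nn23)cc(OC)c1OC` gives 378 nM
compound 2 `COc1cc(-c2ccnc3cc(-c4ccc5cnn(C)c5c4)nn23)cc(OC)c1OC` gives 97 nM
compound 3 `COc1ccc(-c2cc3nccc(-c4cc(OC)c(OC)c(OC)c4)n3n2)cc1N` gives 283 nM

Compound 3 stands in the middle of the three numbers, as a 1.3-fold lower number from compound 1 to compound 3 (0.13 log units; within the scatter) and a 2.9-fold higher number from compound 2 to compound 3 (0.47 log units; beyond the scatter) show. Compound 4 `COc1cc(-c2ccnc3cc(-c4ccc(C(C)(C)C)cc4)nn23)cc(OC)c1OC` carries 4-(tert-butyl)phenyl in place of 3-amino-4-methoxyphenyl on an aromatic carbon, with this count: 4-(tert-butyl)phenyl in place of 3-amino-4-methoxyphenyl on an aromatic carbon and the rest unchanged.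

Within the data shown here, the closest precedent is a 1.3-fold lower number from compound 1 to compound 3 (0.13 log units; within the scatter) between two substituted phenyl groups. The larger steps of a 3.9-fold lower number from compound 1 to compound 2 (0.59 log units; beyond the scatter) and a 2.9-fold higher number from compound 2 to compound 3 (0.47 log units; beyond the scatter) both involve 1-methyl-1H-indazol-6-yl, which compound 4 lacks. No step beyond the scatter is therefore expected in this assay, and the estimate is a 1.2-fold higher number from compound 3 to compound 4 (0.09 log units; within the scatter) in a slightly higher direction. For compound 4 the estimated value is 350 nM within an expected range of 120 nM to 1000 nM.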

Compound 4, half-maximal inhibitory concentration: > 10000 nM
Compound 4: a limit, no number (the forecaster's own chance of this, stated with the estimate: 5%); at least 28-fold (1.45 log units) between middle value and limit.
By their numbers in this assay, from the lowest: compound 2; then compounds 3 and 1 (each within the scatter of the next). At a limit, above all of these: compound 4.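

At this position on the shared core, the aryl group is not freely exchangeable: the earlier swap between two substituted phenyl groups stayed within the scatter, whereas 4-(tert-butyl)phenyl gives an at least 35-fold higher number from compound 3 to compound 4 (1.54 log units; beyond the scatter) and an at least 100-fold higher number from compound 2 to compound 4 (2.01 log units; beyond the scatter). With the phenyl ring kept, tert-butyl in place of dimethylamino alone gives an at least 26-fold higher number from compound 1 to compound 4 (1.42 log units; beyond the scatter). The reading for compound 4 is a limit and not a number: the limit of > 10000 nM in this assay, at which 1 of the 4 values shown sits.

As far as these compounds go, it remains open how a methyl, methoxy or primary amine group on the same phenyl ring would read. The compounds shown also do not separate the tert-butyl group itself from the loss of any nitrogen or oxygen in the entering group.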